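The compounds below may be only part of what the source reports. "The series", "measured", "known", "first", "only" and "open" are said of these compounds alone.

Compound 3, `COc1ccc(F)cc1CNCCCNc1ccnc2cc(Cc3ccccc3)ccc12`, sits among three close relatives that share one core and differ only in the group hung on a saturated chain carbon bound to an aromatic carbon. In a physicochemical assay for solubility, with a stated time of 18 h, at pH 7.4 (on this read-out lower numbers stand for lower solubility and higher numbers for higher solubility), compound 3 gives 4200 nM. Compound 1, `COc1ccc(F)cc1CNCCCNc1ccnc2cc(Cc3cc(C)cc(C)c3)ccc12`, gives 4200 nM in this assay, and compound 2, `COc1ccc(F)cc1CNCCCNc1ccnc2cc(CC(C)C)ccc12`, gives 4200 nM. The steps among them are small: no change at the digits printed from compound 1 to compound 2 (within the scatter), no change at the digits printed from compound 1 to compound 3 (within the scatter) and no change at the digits printed from compound 2 to compound 3 (within the scatter). Compound 3 therefore stands level with compounds 1 and 2 at the digits shown.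

Compound 4, `COc1ccc(F)cc1CNCCCNc1ccnc2cc(-c3ccc(C(C)(C)C)cc3)ccc12`, has not yet been measured. Its change from compound 3 is 4-(tert-butyl)phenyl in place of benzyl on an aromatic carbon; the new group sits on an aromatic carbon of a six-membered aromatic ring of carbon only, part of a fused or bridged system of two rings, meta to a fused ring and para to a fused ring. Within the data shown here, no measured step swaps a benzyl for an aryl group directly bound to the ring; the three steps seen only exchange groups on the saturated chain carbon, and each of them left this assay unchanged within the scatter. On that basis the expected step from compound 3 to compound 4 is a 1.2-fold lower number from compound 3 to compound 4 (0.08 log units; within the scatter), with no change beyond the scatter expected. Compound 4 is estimated at 3500 nM, with a range from 1200 nM to 9000 nM.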

Compound 4, solubility: 32000 nM
Beside the measured number, compound 4's estimate is 9.1-fold (0.96 log units) below it; measured number above the stated range.
By their numbers in this assay, from the lowest: compounds 1, 2 and 3 (each within the scatter of the next); then compound 4.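

Replacing benzyl with 4-(tert-butyl)phenyl on the aromatic carbon gives a 7.6-fold higher number from compound 3 to compound 4 (0.88 log units; beyond the scatter) in this assay, and the matching replacements of isobutyl and 3,5-dimethylbenzyl give a 7.6-fold higher number from compound 2 to compound 4 (0.88 log units; beyond the scatter) and a 7.6-fold higher number from compound 1 to compound 4 (0.88 log units; beyond the scatter). Among these compounds, this is the first step to go beyond the scatter, so the read-out at this position is not indifferent to every change: exchanging groups on the saturated chain carbon left the number in place, whereas this change, which removes that chain carbon and brings in a tert-butyl-bearing phenyl ring, moved it. No supporting measurement bears on why the number rises.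

The shown compounds change both features at once, so they do not separate the effect of losing the saturated chain carbon from that of adding the tert-butyl group; an unsubstituted phenyl on the same aromatic carbon and a 4-(tert-butyl)benzyl group would pull the two apart. Also open, on these data alone, is how this position responds to a group of another kind, such as a morpholine or a carboxylic acid, in place of these all-carbon groups.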